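Trading a pyrrolidine amide for a methylaminomethyl arm

A few compounds are considered here, and "the series" means these few. Any claim that something is new, unique, unknown or untested is made for them only; others in the source may bear on it.

Compound 3 `CCCCCOC(=O)N1CCN(C(=O)[C@H](CCC(=O)O)NC(=O)c2cc(N3CCC(C(=O)N4CCCC4)CC3)nc(-c3ccccc3)n2)CC1` was examined in an ADME assay on microsomes from liver (Rattus norvegicus) for metabolic stability; a lower number here means that less of the compound is left, a higher number that more of the compound is left. In this assay compound 3 gives > 80%, which is a limit of the assay rather than a number. Two relatives share its core and differ only at one saturated ring carbon of the six-membered ring with one nitrogen. Compound 1 `CCCCCOC(=O)N1CCN(C(=O)[C@H](CCC(=O)O)NC(=O)c2cc(N3CCC(C(=O)NCC)CC3)nc(-c3ccccc3)n2)CC1` gives > 80% in this assay, again a limit. Compound 2 `CCCCCOC(=O)N1CCN(C(=O)[C@H](CCC(=O)O)NC(=O)c2cc(N3CCC(N4CCCC4)CC3)nc(-c3ccccc3)n2)CC1` gives > 80%, also a limit. The three steps between them, a step that the two limits leave unreadable from compound 1 to compound 2, a step that the two limits leave unreadable from compound 1 to compound 3 and a step that the two limits leave unreadable from compound 2 to compound 3, cannot be sized because of the limit of > 80% in this assay, at which 3 of the 3 values shown sit. Compound 4 `CCCCCOC(=O)N1CCN(C(=O)[C@H](CCC(=O)O)NC(=O)c2cc(N3CCC(CNC)CC3)nc(-c3ccccc3)n2)CC1` is the next variation at that same ring carbon: (methylamino)methyl in place of (pyrrolidin-1-yl)carbonyl on a saturated ring carbon. The group that enters brings one hydrogen-bond donor where the group that leaves had none, and it has no ring. Since every earlier change at this position left the reading at the limit, no step beyond the scatter is expected here, and the step from compound 3 to compound 4 is estimated as a number no higher from compound 3 to compound 4 (the limit leaves the size open). Compound 4 is therefore expected to give about 80%, most likely between 55% and 95%.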

Compound 4, percent of the compound remaining: > 80%
Compound 4: only a limit was reported (the forecaster's own chance of this, stated with the estimate: 55%); the middle value sits exactly at the limit.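

In this assay compound 4 gives > 80%, which is a limit and not a number. Its steps from compound 1, compound 2 and compound 3 cannot be read because the readings stop at the same limit: the limit of > 80% in this assay, at which 4 of the 4 values shown sit.

As far as these compounds go, whether these four compounds truly differ in this assay stays open.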